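The compounds below may be only part of what the source reports. "The series", "measured", "known", "first", "only" and "open" are said of these compounds alone.

Working notes on the series.

Compound 1 `COc1cc(-c2nn(-c3cccc(NC(=O)c4ccc(Cl)c(C(F)(F)F)c4)c3)cc2-c2ccncc2)ccc1Cl` sits in a functional assay on HT-29 cells (Homo sapiens) for inhibition, read by sulforhodamine B assay, with a stated time of 48 h (on this read-out lower numbers stand for higher toxicity in this test and higher numbers for lower toxicity in this test), at a limit of the assay, > 32500 nM, with no number behind it. Compound 2 `O=C(Nc1cccc(-n2cc(-c3ccncc3)c(-c3ccc(Cl)c(O)c3)n2)c1)Nc1cccc(C(F)(F)F)c1` also stops at a limit in this assay, > 32500 nM. Compound 3 `O=C(Nc1cccc(-n2cc(-c3ccncc3)c(-c3ccc(Cl)c(O)c3)n2)c1)Nc1ccc(Cl)c(C(F)(F)F)c1` gives a number in this assay, 22600 nM, and the step of an at least 1.4-fold lower number from compound 2 to compound 3 (0.15 log units; that floor lies within the scatter) is chloro in place of hydrogen on an aromatic carbon. Two of the three values rest on (the limit of > 32500 nM in this assay, at which 2 of the 3 values shown sit), so little room is left to read the series.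

Compound 4 `COc1cc(-c2nn(-c3cccc(NC(=O)Nc4ccc(Cl)c(Cl)c4)c3)cc2-c2ccncc2)ccc1Cl` differs from compound 1 by (3,4-dichlorophenyl)amino in place of 4-chloro-3-(trifluoromethyl)phenyl on a carbonyl carbon. Among the measured compounds shown here, the only measured step concerns a different change and barely leaves the scatter, so compound 4 is expected to move an at least 1.0-fold lower number from compound 1 to compound 4 (0.03 log units; that floor lies within the scatter), that is, no step beyond the scatter. Compound 4 is thus estimated at 30000 nM, expected between 12000 nM and 60000 nM.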

Compound 4, concentration lethal to 50% of the cells: > 50000 nM
Compound 4 gave a limit, no number (the forecaster's own chance of this, stated with the estimate: 55%); middle value at least 1.6-fold (0.22 log units) away from the limit.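

In this assay compound 4 stops at a limit, > 50000 nM. Among the compounds shown here, compound 1 also stops at a limit, > 32500 nM, and no step from compound 1 to compound 4 can be read. The compounds shown leave open whether (3,4-dichlorophenyl)amino in place of 4-chloro-3-(trifluoromethyl)phenyl changes this read-out at all.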